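Sulfonate and sulfonamide ureas on colon cells

A few compounds are considered here, and "the series" means these few. Any claim that something is new, unique, unknown or untested is made for them only; others in the source may bear on it.

Compound 1 `CCNC(=O)Nc1ccc(S(=O)(=O)Oc2ccccc2C)cc1` and compound 2 `CCNC(=O)Nc1ccc(S(=O)(=O)Oc2ccccc2CC)cc1` share one core; compound 3 `CCNC(=O)Nc1ccc(S(=O)(=O)Nc2ccccc2CC)cc1` carries another, and the difference between the two cores is not broken down here. In a functional assay on HT-29 cells (Homo sapiens) for cytotoxicity, read by sulforhodamine B assay, with a stated time of 48 h (a lower number here means a stronger inhibitor, a higher number a weaker inhibitor), compound 1 gives 12000 nM, compound 2 gives 12000 nM and compound 3 gives 86000 nM. The change methyl in place of hydrogen on a saturated chain carbon bound to an aromatic carbon made no change at the digits printed from compound 1 to compound 2 (within the scatter). Compound 4 `CCCc1ccccc1NS(=O)(=O)c1ccc(NC(=O)NCC)cc1` is not yet measured; it arises from compound 3 by methyl in place of hydrogen on a saturated chain carbon, two bonds along the chain from an aromatic carbon. This is the same kind of change, though its place is a saturated chain carbon two bonds along the chain from an aromatic carbon rather than one bound to an aromatic carbon. Since the earlier methyl made no change at the digits printed from compound 1 to compound 2 (within the scatter), the step of a 1.1-fold lower number from compound 3 to compound 4 (0.03 log units; within the scatter) is expected to be of similar size, near none. Compound 4 is estimated at 80000 nM, between 35000 nM and 180000 nM.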

Compound 4, half-maximal inhibitory concentration: 32000 nM
Compound 4: middle estimate off by 2.5-fold (0.40 log units), on the high side; measured number outside the range, below it.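

In this assay, the methyl added to the chain of compound 3 gives a 2.7-fold lower number from compound 3 to compound 4 (0.43 log units; beyond the scatter). The size of this step therefore does not carry over unchanged between the two cores: the same change on two cores in this assay, no change at the digits printed (within the scatter) from compound 1 to compound 2 and a 2.7-fold lower number (0.43 log units; beyond the scatter) from compound 3 to compound 4, 2.7-fold (0.43 log units) apart, beyond the scatter of two such steps

The two steps also differ in place, one on a saturated chain carbon bound to an aromatic carbon and the other on a carbon two bonds along the chain, so the gap cannot be assigned to the core alone, and one step per core sets no rule for the series.

Still open, going by these compounds, is how the propyl chain of compound 4 would behave on the core of compound 1, which would separate core from place. Also open, on these data alone, is whether a longer chain, such as butyl, would extend the step from compound 3 to compound 4.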